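A few compounds are considered here, and "the series" means these few. Any claim that something is new, unique, unknown or untested is made for them only; others in the source may bear on it.

Three related compounds have been examined so far: compound 1 `COc1cc(/C=C/C(=O)Nc2cc3c(Nc4ccc(F)c(Cl)c4)ncnc3cc2O[C@H]2CCOC2)cc(OC)c1OC`, compound 2 `O=C(/C=C/c1cc(Br)c(O)c(Br)c1)Nc1cc2c(Nc3ccc(F)c(Cl)c3)ncnc2cc1O[C@H]1CCOC1` and compound 3 `COc1cc2ncnc(Nc3ccc(F)c(Cl)c3)c2cc1NC(=O)/C=C/c1cc(OC)c(OC)c(OC)c1`. In a functional assay on HeLa cells (Homo sapiens) for cytotoxicity, read by MTT assay, with a stated time of 72 h (a higher number here means a weaker inhibitor, a lower number a stronger inhibitor), compound 1 gives 24500 nM and compound 2 gives 27700 nM, while compound 3 is recorded as "not determined" (no result reported). Going by the values given here, compound 2 therefore stands level with compound 1, the only other compound with a number. The next structure, compound 4 `O=C(/C=C/c1ccc(Br)cc1)Nc1cc2c(Nc3ccc(F)c(Cl)c3)ncnc2cc1O[C@H]1CCOC1`, arises from compound 2 through one change, 4-bromophenyl in place of 3,5-dibromo-4-hydroxyphenyl on a double-bonded chain carbon bound to a double-bonded chain carbon. Among the compounds with values here, only one measured step bears on this place, a 1.1-fold higher number from compound 1 to compound 2 (0.05 log units; within the scatter), which brought in 3,5-dibromo-4-hydroxyphenyl in place of 3,4,5-trimethoxyphenyl. That single step is thin evidence, but it gives no reason to expect a shift beyond the scatter in this assay. The expected result is a 1.2-fold lower number from compound 2 to compound 4 (0.08 log units; within the scatter). Compound 4 is estimated at 23000 nM, with an expected range from 10000 nM to 50000 nM.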

Compound 4, half-maximal inhibitory concentration: 27500 nM
Compound 4: middle estimate off by 1.2-fold (0.08 log units), on the low side, and the stated range covers the measured number.
By their numbers in this assay, from the lowest: compounds 1, 4 and 2 (each within the scatter of the next).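

In this assay, 4-bromophenyl in place of 3,5-dibromo-4-hydroxyphenyl gives a 1.0-fold lower number from compound 2 to compound 4 (0.00 log units; within the scatter), so at this position a group with 0 hydrogen-bond donors and 0 hydrogen-bond acceptors stands level with one that has 1 of each. Against 3,4,5-trimethoxyphenyl the same group gives a 1.1-fold higher number from compound 1 to compound 4 (0.05 log units; within the scatter), which means that all three aryl groups tried on the double-bonded chain carbon now lie within the scatter of one another, where the earlier compounds offered only a single such comparison. Nothing at hand offers an explanation for this flat result.

Going by these compounds, whether it would hold for a phenyl ring bearing an amine or a carboxylic acid, or for a longer chain at this place, remains open. Compound 3 has no number, so the effect of its methoxy group in place of the ether ring on the core cannot be judged.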